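A few compounds are considered here, and "the series" means these few. Any claim that something is new, unique, unknown or untested is made for them only; others in the source may bear on it.

Measured in a functional assay (mast cells) for inhibition, with Rattus norvegicus as the target; on this read-out higher numbers stand for an effect only at larger amounts of compound and lower numbers for an effect already at smaller amounts:
- compound 1 `CC1CC/C(=N\Nc2cccc(C(=O)O)c2)c2nccc(=O)n21` gives 655000 nM
- compound 2 `CC1CC/C(=N\Nc2ccc(F)cc2)c2ncc(C(=O)O)c(=O)n21` gives 1200 nM

Compound 2 has the lower of the two numbers in this assay, and its gap to compound 1 lies beyond the scatter. These two compounds differ in more than one place, so their gap does not size any single change.

Compound 3 `CC(=O)c1ccc(N/N=C2\CCC(C)n3c2ncc(C(=O)O)c3=O)cc1` has acetyl in place of fluoro on an aromatic carbon, para to a large group, and is otherwise the same as compound 2 . The counted difference is acetyl in place of fluoro on an aromatic carbon. Among the compounds with values here, no measured pair isolates a change at this place, so the expectation here is tentative. The expected move in this assay is a 1.5-fold lower number from compound 2 to compound 3 (0.18 log units; within the scatter), slightly towards a lower number but with no step beyond the scatter. For compound 3 the estimated value is 800 nM, with an expected range from 150 nM to 4000 nM.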

Compound 3, half-maximal effective concentration: 8100 nM
Compound 3: the middle estimate sits 10-fold (1.01 log units) below what was measured, and the stated range ends below it.
By their numbers in this assay, from the lowest: compound 2; then compound 3; then compound 1.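

Within the data shown here, this pair is the first to isolate a single change at this place: in this assay, acetyl in place of fluoro on an aromatic carbon, para to a large group, gives a 6.8-fold higher number from compound 2 to compound 3 (0.83 log units; beyond the scatter). The position therefore responds to what it carries, and of the two groups tested on this shared core, fluoro goes with the lower number. Nothing measured here bears on why the number moves.

The compounds shown leave open where an amine, a methoxy group or a chloro group at this place would fall relative to compound 2 and compound 3. Among these compounds, with only two groups compared at this position, they also leave open whether any trend runs across substituents here, or whether the step belongs to acetyl alone.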